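Imidazoline to imidazole on a naphthol amine

A few compounds are considered here, and "the series" means these few. Any claim that something is new, unique, unknown or untested is made for them only; others in the source may bear on it.

compound 1 `CCN(CC)C(=O)c1ccccc1OCC1=NCCN1` — < 100000 nM
compound 2 `CCN(CC)C(=O)c1ccccc1OCc1c[nH]cn1` — < 100000 nM
compound 3 `Oc1ccc2cccc(NCC3=NCCN3)c2c1` — 6.31 nM

In a functional assay for activation of Alpha-1A adrenergic receptor (Homo sapiens) (on this read-out higher numbers stand for an effect only at larger amounts of compound and lower numbers for an effect already at smaller amounts), compound 1 gives < 100000 nM, which is a limit of the assay and not a number. Compound 2 gives < 100000 nM in this assay, again a limit. Because both sit at the limit of < 100000 nM in this assay, at which 2 of the 3 values shown sit, the step that the two limits leave unreadable from compound 1 to compound 2 cannot be sized. Among the measured compounds shown here, compound 3 gives 6.31 nM in this assay, the only number among the three. How the core of compound 3 differs from the core of compound 1 is not broken down here.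

Compound 4 `Oc1ccc2cccc(NCc3c[nH]cn3)c2c1` is not yet measured. It differs from compound 3 by a group of 5 heavy atoms (3 carbon, 2 nitrogen; one five-membered aromatic ring with 2 hetero atoms) in place of a group of 5 heavy atoms (3 carbon, 2 nitrogen; one five-membered non-aromatic ring with 2 hetero atoms), on a saturated chain carbon bound to a nitrogen on an aromatic ring. This is the same kind of change as a group of 5 heavy atoms (3 carbon, 2 nitrogen; one five-membered aromatic ring with 2 hetero atoms) in place of a group of 5 heavy atoms (3 carbon, 2 nitrogen; one five-membered non-aromatic ring with 2 hetero atoms), on a saturated chain carbon bound to an oxygen on an aromatic ring, though there the group sits on a saturated chain carbon bound to an oxygen on an aromatic ring, and here on a saturated chain carbon bound to a nitrogen on an aromatic ring. Beside that unreadable earlier step, the step from compound 3 to compound 4 is expected to be a 32-fold higher number from compound 3 to compound 4 (1.50 log units; beyond the scatter), a loss of potency; this rests only on the starting value of compound 3, 6.31 nM, since the measured pair gives no size. Compound 4 is thus estimated at 200 nM, expected between 20 nM and 3000 nM.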

Compound 4, half-maximal effective concentration: 63.1 nM
The estimate for compound 4 lay 3.2-fold (0.50 log units) above the measured number, within the range that was stated.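

In this assay, putting 1H-imidazol-4-yl in place of the five-membered non-aromatic ring, on a saturated chain carbon bound to a nitrogen on an aromatic ring, gives a 10-fold higher number from compound 3 to compound 4 (1.00 log units; beyond the scatter) as a modest loss of potency, and compound 4 still gives a real number. The same swap on the core of compound 1 cannot be read, because compound 1 and compound 2 each give a limit of the assay and not a number: the limit of < 100000 nM in this assay, at which 2 of the 4 values shown sit. The change therefore has a measured size on one core only, and nothing here shows that this size carries over to the core of compound 1.

The compounds shown leave open how the swap behaves with a longer chain linking the five-membered ring to the core, or with a methoxy group in place of the hydroxyl of compound 3 and compound 4. They also leave open whether the step keeps its size on any further core where both partners give a number.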